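The source may report more compounds than this note shows. Statements on the series, on what has been measured and on what is new or still open speak of the compounds shown alone.

Compounds measured so far, in an ADME assay on MDCK cells (Canis lupus familiaris) for cytotoxicity, read by microscopy, with a stated time of 48 h; a lower number here means that less compound is tolerated, a higher number that more compound is tolerated:

Compound 1, `CCCCc1csc(CN[C@@H]2C[C@H]3C[C@@H]([C@H]2C)C3(C)C)c1`, gives 12500 nM.
Compound 2, `C[C@H]1[C@H](NCc2cc(-c3ccccc3)cs2)C[C@H]2C[C@@H]1C2(C)C`, gives 5000 nM.
Compound 3, `Cc1csc(CN[C@@H]2C[C@H]3C[C@@H]([C@H]2C)C3(C)C)c1`, gives 12500 nM.

Compound 3 stands level with compound 1 at the digits shown, and the two together give the highest numbers of the three, meaning the most compound tolerated. Going by the values given here, the only step that reaches beyond the scatter is a 2.5-fold higher number from compound 2 to compound 3 (0.40 log units; beyond the scatter), a modest one, while no change at the digits printed from compound 1 to compound 3 (within the scatter) shows that exchanging a longer chain for a shorter one left the number where it was.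

Compound 4, `C[C@H]1[C@H](NCc2cc(C3CCCC3)cs2)C[C@H]2C[C@@H]1C2(C)C`, is the next compound. cyclopentyl in place of methyl on an aromatic carbon

A cyclopentyl group is larger than methyl and carries a ring, which makes the step from compound 2 to compound 3, where a phenyl ring was replaced, the closer guide; the step from compound 1 to compound 3 suggests that chain length alone did little. A modest downward move is therefore expected, though smaller than a full return to the phenyl value. For compound 4 the estimate in this assay is 8000 nM, with a range from 4000 nM to 16000 nM, corresponding to the expected step of a 1.6-fold lower number from compound 3 to compound 4 (0.19 log units; within the scatter).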

Compound 4, minimum cytotoxic concentration: 1560 nM
Compound 4: middle estimate off by 5.1-fold (0.71 log units), on the high side; measured number below the stated range.
By their numbers in this assay, from the lowest: compound 4; then compound 2; then compounds 1 and 3 (each within the scatter of the next).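

At this position, two ring bonds from the ring sulfur, this assay now shows that a non-aromatic ring can lower the number well past anything seen before, with an 8.0-fold lower number from compound 3 to compound 4 (0.90 log units; beyond the scatter) and, against the butyl chain, an 8.0-fold lower number from compound 1 to compound 4 (0.90 log units; beyond the scatter). Cyclopentyl also falls clearly short of the aromatic phenyl ring, with a 3.2-fold lower number from compound 2 to compound 4 (0.51 log units; beyond the scatter), so the two ring-bearing groups differ from each other, while both give lower numbers than the methyl and butyl groups, which stand level. Nothing measured here explains why the cyclopentyl compound is tolerated least.

From the compounds shown here alone, what remains open is how the number depends on ring size and ring makeup at this position. A smaller cyclopropyl ring, a larger cyclohexyl ring or an oxygen-containing tetrahydropyranyl ring would help separate these two factors.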